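Trading methyl for hydrogen on the ring of compound 1

The compounds below may be only part of what the source reports. "The series", "measured", "known", "first", "only" and "open" are said of these compounds alone.

The measured compounds:
- compound 1, `Cc1ccc([C@]2(CO)NC[C@@H](O)[C@@H]2O)cc1`, with 1.6% in an assay on isolated protein for inhibition of alpha-galactosidase (Coffea arabica), tested at 1000 uM; a higher number here means more inhibition at the concentration tested (going by the name of the read-out), a lower number less inhibition
- compound 2, `CCCCCCCCC[C@]1(CO)NC[C@@H](O)[C@@H]1O`, with 2.5% in this assay
- compound 3, `Cc1ccc([C@@]2(CO)NC[C@H](O)[C@H]2O)cc1`, with 0% in this assay

All three numbers are small. Compound 1 stands second highest of the three; its nearest neighbour is compound 2, whose number lies above it but within the scatter, and its furthest is compound 3, whose number lies below it, also within the scatter. Compound 1 and compound 3 are mirror images of one another (the fact that compounds 1 and 3 differ only in the configuration as drawn), and the step between them is a number 1.6 percentage points lower from compound 1 to compound 3 (within the scatter), so inverting every stereocentre of the core leaves the read-out where it was.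

Compound 4, `OC[C@@]1(c2ccccc2)NC[C@@H](O)[C@@H]1O`, is reached from compound 1 by a single change: hydrogen in place of methyl on an aromatic carbon. Among the compounds with values here, no measured step exchanges the methyl on the aromatic ring, so there is nothing to copy from directly. Within the data shown here, the only measured step, the mirror inversion from compound 1 to compound 3, stayed within the scatter, and all three measured numbers sit close together near the bottom of the scale. The expectation for compound 4 is therefore a step of a number 0.1 percentage points lower from compound 1 to compound 4 (within the scatter), that is, none beyond the scatter. Compound 4 is estimated to give 1.5%, within a range from 0% to 10%.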

Compound 4, a percentage reported as inhibition, at one concentration (the size of the read-out at that concentration, not a potency): 9.9%
Compound 4: middle estimate off by 8.4 percentage points, on the low side, within the range that was stated.
By their numbers in this assay, from the lowest: compounds 3, 1, 2 and 4 (each within the scatter of the next).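

Within the data shown here, the exchange of hydrogen for methyl on the aromatic carbon para to a group of 9 heavy atoms is the first measured step at this position, and in this assay it comes out as a number 8.3 percentage points higher from compound 1 to compound 4 (within the scatter). The methyl can therefore be removed without a change that stands clear of the usual scatter, so this pair gives no firm sign that the group matters for the read-out, and the numbers of both compounds remain low on the percentage scale at the single concentration tested. Nothing at hand bears on why this exchange gives the number it does, as the only known structural relation concerns a different pair of compounds.

Still open, on these data alone, is whether a different group at this same place, such as a methoxy, a chlorine, an amine or a carboxylic acid, would move the number beyond the scatter, or whether this position stays as flat as the pair suggests. Also open is how the mirror image of compound 4 would read, since the mirror pair shown carries the methyl and says nothing about the ring with hydrogen in its place.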